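Removing a Trifluoromethyl from a Benzamide in a Growth Assay

The compounds below may be only part of what the source reports. "The series", "measured", "known", "first", "only" and "open" are said of these compounds alone.

Measured compounds:
- compound 1, `COc1cc(-c2nn(-c3cccc(NC(=O)c4cccc(C(F)(F)F)c4)c3)cc2-c2ccncc2)ccc1Cl` — 9270 nM
- compound 2, `O=C(Nc1cccc(-n2cc(-c3ccncc3)c(-c3ccc(Cl)c(O)c3)n2)c1)Nc1cc(C(F)(F)F)cc(C(F)(F)F)c1` — 1480 nM

Of the compounds shown here, two have been measured in a functional assay on NCI-H460 cells (Homo sapiens) for inhibition, read by sulforhodamine B assay, with a stated time of 48 h; a lower number here means a stronger inhibitor of growth, a higher number a weaker inhibitor of growth. Compound 1, `COc1cc(-c2nn(-c3cccc(NC(=O)c4cccc(C(F)(F)F)c4)c3)cc2-c2ccncc2)ccc1Cl`, gives 9270 nM. Compound 2, `O=C(Nc1cccc(-n2cc(-c3ccncc3)c(-c3ccc(Cl)c(O)c3)n2)c1)Nc1cc(C(F)(F)F)cc(C(F)(F)F)c1`, gives 1480 nM. Of these two numbers, compound 1 has the higher one, and the gap to compound 2 is beyond the usual scatter, so compound 1 is the weaker growth inhibitor of the pair. Compound 2 differs from compound 1 in more than one place, so no single change can be read from their values.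

Compound 3, `COc1cc(-c2nn(-c3cccc(NC(=O)c4ccccc4)c3)cc2-c2ccncc2)ccc1Cl`, has not yet been measured. It differs from compound 1 in one place: hydrogen in place of trifluoromethyl on an aromatic carbon. In words, a hydrogen replaces a trifluoromethyl on an aromatic carbon of the benzoyl part. Among the measured compounds shown here, no measured pair shows this single change, so its size in this assay is open. Stripping a group of this kind from an already weak compound is expected to give a higher number, a step from compound 1 to compound 3 of a 2.7-fold higher number from compound 1 to compound 3 (0.43 log units; beyond the scatter). For compound 3 the estimate is 25000 nM, with a likely range from 8000 nM to 80000 nM.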

Compound 3, concentration for total growth inhibition: > 100000 nM
Compound 3 ended at the assay's limit; the forecaster's own chance of this, stated with the estimate: 20%; at least 4.0-fold (0.60 log units) between middle value and limit.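

In this assay, among the compounds shown here, the earlier compounds gave no view of what the trifluoromethyl on the benzoyl part contributes, and this single change now gives one: replacing it with hydrogen produces an at least 10-fold higher number from compound 1 to compound 3 (1.03 log units; beyond the scatter). Compound 1 is already a modest growth inhibitor, yet in this pair the activity it does have depends on keeping that group on the aromatic carbon, and plain benzoyl does not retain it. Compound 3 gives > 100000 nM, which is a limit of the assay and not a number, so the step is a lower bound and its true size remains unknown, because compound 3 sits at the limit: the limit of > 100000 nM in this assay, at which 1 of the 3 values shown sits.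

This pair shows only that the trifluoromethyl cannot simply be removed, and leaves open whether a methyl, a chlorine atom or a nitrile on the same aromatic carbon would keep the growth inhibition of compound 1. It also leaves open whether the same change would matter as much in another setting, since compound 2 differs from compound 1 in more than one place and cannot answer that question.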